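Compound 3: a swapped group on a carbonyl carbon

The source may hold more compounds than are shown below. What is called first, only, known or untested is meant among the compounds shown, and "the series" means these compounds.

Measured in a functional assay on C8166 cells (Homo sapiens) for cytotoxicity, read by MTT assay; a lower number here means that less compound is tolerated, a higher number that more compound is tolerated:
- compound 1 `Cc1cc(S(N)(=O)=O)ccc1NC(=O)COc1ccc(Cl)cc1NC(=O)c1cccc(Cl)c1`: 59700 nM
- compound 2 `Cc1cc(S(N)(=O)=O)ccc1NC(=O)COc1ccc(Cl)cc1NC(=O)c1ccccc1[N+](=O)[O-]`: 54800 nM

Compound 2 cannot be told apart from compound 1 on these numbers, since the two lie within the usual scatter of each other. Compound 3 `Cc1ccc(C(=O)Nc2cc(Cl)ccc2OCC(=O)Nc2ccc(S(N)(=O)=O)cc2C)cc1C`, not yet measured, alters compound 2 at one place: 3,4-dimethylphenyl in place of 2-nitrophenyl on a carbonyl carbon. Among the compounds with values here, the only measured step at this place is a 1.1-fold lower number from compound 1 to compound 2 (0.04 log units; within the scatter), which stayed within the scatter. Within the data shown here, no measured compound carries the 3,4-dimethylphenyl group, so this is a weak guide, and no shift beyond the scatter is expected. The expected step is a 1.0-fold higher number from compound 2 to compound 3 (0.00 log units; within the scatter). Compound 3 is estimated at 55000 nM, with an expected range of 27000 nM to 110000 nM.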

Compound 3, half-maximal cytotoxic concentration: 84100 nM
The estimate for compound 3 lay 1.5-fold (0.18 log units) below the measured number; measured number inside the range.
By their numbers in this assay, from the lowest: compounds 2, 1 and 3 (each within the scatter of the next).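

In this assay the data show a 1.5-fold higher number from compound 2 to compound 3 (0.19 log units; within the scatter) and a 1.4-fold higher number from compound 1 to compound 3 (0.15 log units; within the scatter) when 3,4-dimethylphenyl sits on the carbonyl carbon. A group built of carbon alone, with neither the nitro group nor the chlorine, therefore stays within the scatter of both earlier compounds, so three different substituted phenyl groups at this place cannot be told apart. Nothing available offers an explanation for this result.

Still open, going by these compounds, is whether a different kind of group at this place, such as an amine or a carboxylic acid, would move the number beyond the scatter.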